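The source may report more compounds than this note shows. Statements on the series, on what has been measured and on what is new or still open speak of the compounds shown alone.

Compound 1, `Cc1nccc2nn(-c3ccccc3)cc12`, reaches only the assay limit of > 100000 nM in a functional assay on MCF7 cells (Homo sapiens) for inhibition, read by fluorescence, with a stated time of 72 h; a higher number here means a weaker inhibitor of growth, a lower number a stronger inhibitor of growth. Compound 2, `CC(C)c1nc(-c2ccccc2)cc2nn(-c3ccccc3)cc12`, gives 91000 nM in this assay. This is the only number shown; the other value is a limit (the limit of > 100000 nM in this assay, at which 1 of the 2 values shown sits), so compound 2 stands alone among the numbers. Compound 3, `CC(C)c1nccc2nn(-c3ccccc3)cc12`, differs from compound 2 by hydrogen in place of phenyl on an aromatic carbon. Within the data shown here, no step between measured compounds is available, yet compound 1, which also lacks the phenyl, sits at the limit (the limit of > 100000 nM in this assay, at which 1 of the 2 values shown sits). The expected step is a 1.8-fold higher number from compound 2 to compound 3 (0.25 log units; within the scatter), toward weaker inhibition, beyond the scatter. Compound 3 is therefore estimated at 160000 nM, within 60000 nM to 400000 nM, with a fair chance that only a limit is reported.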

Compound 3, concentration for 50% growth inhibition: 98800 nM
Compound 3: middle estimate off by 1.6-fold (0.21 log units), on the high side; measured number inside the range.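

In this assay, hydrogen in place of phenyl gives a 1.1-fold higher number from compound 2 to compound 3 (0.04 log units; within the scatter), so in this pair the phenyl on this aromatic carbon brings no readable change in growth inhibition. Isopropyl in place of methyl on an aromatic carbon gives an at least 1.0-fold lower number from compound 1 to compound 3 (0.00 log units; that floor lies within the scatter); this step is read against a limit and sets only a floor, so its true size stays unknown. The numbers for compound 2 and compound 3 stand close to that limit, which leaves little room to read any change: the limit of > 100000 nM in this assay, at which 1 of the 3 values shown sits.

Still open, as far as these compounds go, is whether an amine or a carboxylic acid on this aromatic carbon, or a longer chain in place of isopropyl, would move the number at all.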